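The source may hold more compounds than are shown below. What is called first, only, known or untested is meant among the compounds shown, and "the series" means these compounds.

Compound 1 `CC1CCN(C2CCN(S(=O)(=O)c3cccc(Br)c3)CC2)CC1` and compound 2 `COc1ccc(OC)c(S(=O)(=O)N2CCC(N3CCC(C)CC3)CC2)c1` share a core and differ only in what sits on the aromatic ring of the sulfonyl part. In a functional assay on DLD-1 cells (Homo sapiens) for antiproliferative activity, read by CellTiter-Glo, with a stated time of 72 h (a lower number here means a stronger inhibitor, a higher number a weaker inhibitor), compound 1 gives 3.2 nM. In this assay compound 2 gives 4.5 nM, a number that lies within the usual scatter of the number for compound 1, so the two cannot be told apart on these data. Compound 3 `COc1ccc(Br)cc1S(=O)(=O)N1CCC(N2CCC(C)CC2)CC1` has not yet been measured. It arises from compound 2 by one change: bromo in place of methoxy on an aromatic carbon. Among the measured compounds shown here, no measured pair shows this exact change, so its size can only be anticipated. Compound 1 already carries a bromo group on its aromatic ring, and compound 2 carries two methoxy groups, and both give low numbers in this assay; a compound that combines one of each is therefore expected to stay close to both. The expected step of a 1.3-fold lower number from compound 2 to compound 3 (0.11 log units; within the scatter) is none beyond the scatter. Compound 3 is estimated to give about 3.5 nM in this assay, with a likely range from 1.5 nM to 9 nM.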

Compound 3, half-maximal inhibitory concentration: 2 nM
For compound 3 the middle estimate is 1.8-fold (0.24 log units) above the measured one, within the range that was stated.
By their numbers in this assay, from the lowest: compounds 3, 1 and 2 (each within the scatter of the next, the first and the last beyond it).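

At this place on the ring, meta to a large group and para to a methoxy group, bromo in place of methoxy gives a 2.3-fold lower number from compound 2 to compound 3 (0.35 log units; beyond the scatter) in this assay. This is the first step among these compounds that lies beyond the scatter, so the group at this place does register in the read-out, although the step is modest. Methoxy in place of hydrogen on an aromatic carbon gives a 1.6-fold lower number from compound 1 to compound 3 (0.20 log units; within the scatter), a step within the scatter that cannot be told from no change on these data, and nothing available explains either step.

The compounds shown carry only bromo, methoxy or hydrogen on the ring carbons involved, so it stays open how a chloro group, a nitrile or an amine would read at the same place. The shared core is also the same throughout, which leaves open whether the step from methoxy to bromo would hold on a different core.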